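The compounds below may be only part of what the source reports. "The series", "measured", "known", "first", "only" and "open" are said of these compounds alone.

Of the compounds shown here, two have numbers so far in an ADME assay on MT4 cells (Homo sapiens) for cytotoxicity, read by MTT assay; a higher number here means that more compound is tolerated, a lower number that less compound is tolerated. Compound 1 `O=C(CSc1nncnc1-c1ccccc1Cl)Nc1ccc(Cl)cc1Cl` gives 51000 nM, and compound 2 `COC(=O)c1sccc1NC(=O)CSc1nncnc1-c1ccccc1Cl` gives 105000 nM, the higher of the two numbers.

The next compound is compound 3 `O=C(CSc1nncnc1-c1ccccc1Cl)Nc1ccccc1Cl`. It differs from compound 2 at one place, with 2-chlorophenyl in place of 2-(methoxycarbonyl)thiophen-3-yl on an amide-type nitrogen.

Going by the values given here, only one measured step bears on this change: a 2.1-fold higher number from compound 1 to compound 2 (0.31 log units; beyond the scatter), a modest step in which 2-(methoxycarbonyl)thiophen-3-yl replaced 2,4-dichlorophenyl on the same nitrogen. The entering 2-chlorophenyl resembles the 2,4-dichlorophenyl of compound 1 more closely than it resembles the leaving group, so the number is expected to move back towards that of compound 1, 51000 nM. A step to a lower number is therefore expected, similar to or slightly smaller than that measured step. Among the compounds with values here, no measured pair isolates the difference between 2-chlorophenyl and 2,4-dichlorophenyl, so the range stays wide.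

The expected change is a 1.8-fold lower number from compound 2 to compound 3 (0.24 log units; within the scatter). For compound 3 the estimated value is 60000 nM, with an expected range of 30000 nM to 120000 nM.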

Compound 3, half-maximal cytotoxic concentration: 90000 nM
For compound 3 the middle estimate is 1.5-fold (0.18 log units) below the measured one; low and high end bracket the measured number.
By their numbers in this assay, from the lowest: compounds 1, 3 and 2 (each within the scatter of the next, the first and the last beyond it).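

In this assay, 2-chlorophenyl in place of 2-(methoxycarbonyl)thiophen-3-yl on the amide-type nitrogen gives a 1.2-fold lower number from compound 2 to compound 3 (0.07 log units; within the scatter) and so leaves the two groups unseparated, which shows that the thiophene ring and its methoxycarbonyl group are not needed to keep the number within the scatter of that of compound 2. Hydrogen in place of chloro on an aromatic carbon gives a 1.8-fold higher number from compound 1 to compound 3 (0.25 log units; within the scatter) and is the first reading of that single change on the phenyl ring, and it too stays within the scatter. The earlier step of a 2.1-fold higher number from compound 1 to compound 2 (0.31 log units; beyond the scatter) thus now has an intermediate compound on its path, with neither of the two smaller steps beyond the scatter on its own, so the difference between the two end compounds cannot be assigned to one structural feature.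

On these data alone, whether a carboxylic acid in place of the methoxycarbonyl group, or an aliphatic amine or a longer alkyl chain in place of the aromatic ring on the amide-type nitrogen, would keep the number in this range remains open. No measurement at hand accounts for these numbers.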